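A few compounds are considered here, and "the series" means these few. Any claim that something is new, unique, unknown or untested is made for them only; others in the source may bear on it.

Compound 2, `CC1(C(=O)NCCSc2nonc2/C(=N/O)Nc2ccc(F)c(C(F)F)c2)CCN1`, is an inhibitor of an assay for inhibition of Indoleamine 2,3-dioxygenase 1 (Homo sapiens), read by fluorescence, with a stated time of 1 h; a higher number here means a weaker inhibitor, a lower number a stronger inhibitor; in this assay compound 2 gives 360 nM. Among the two compounds with numbers, compound 2 stands at the higher one: the other, compound 1, `NS(=O)(=O)CC(=O)NCCSc1nonc1/C(=N/O)Nc1cccc(Cl)c1`, shows in this assay a value of 21 nM. The two compounds differ in more than one place, so their values are only two points side by side, and no single change can be read from them.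

Compound 3, `N#CCC(=O)NCCSc1nonc1/C(=N/O)Nc1ccc(F)c(C(F)F)c1`, keeps the shared core of compound 2 and its anilino part. The change is a group of 3 heavy atoms (2 carbon, 1 nitrogen; no ring) in place of a group of 5 heavy atoms (4 carbon, 1 nitrogen; one four-membered non-aromatic ring with 1 hetero atom), on a carbonyl carbon. Among the compounds with values here, no pair of measured compounds that differ in this one place is available, so the size of the step cannot be read from the data; the expectation rests on the position of compound 2 alone. The author expects a moderate move toward a lower number, beyond the scatter but well short of the gap to compound 1, which the estimated step of a 3.3-fold lower number from compound 2 to compound 3 (0.51 log units; beyond the scatter) expresses. For compound 3 in this assay the estimate is 110 nM, with a range from 30 nM to 400 nM.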

Compound 3, half-maximal inhibitory concentration: 180 nM
The estimate for compound 3 lay 1.6-fold (0.21 log units) below the measured number; the measured number falls inside the stated range.
By their numbers in this assay, from the lowest: compound 1; then compounds 3 and 2 (each within the scatter of the next).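

Where the four-membered ring group on the carbonyl carbon of compound 2 gives way to cyanomethyl in compound 3, the result in this assay is a 2.0-fold lower number from compound 2 to compound 3 (0.30 log units; within the scatter), with the anilino part and the shared core unchanged. Within the data shown here, this is the first step that can be read at this place, and it shows that these two groups, which differ in size and in the presence of a ring, are not told apart by this assay. No independent measurement bears on this result, so it cannot be explained further here.

Whether a carboxylic acid, a hydroxyl group or a longer alkyl chain on this carbonyl carbon would move the number beyond the scatter remains open, since the two groups shown sample only a small part of what could stand there. Among these compounds, compound 1 differs from compound 2 and compound 3 in more than one place, so no step to it can be read, and how its value divides between the group on the carbonyl carbon and the anilino part also remains open.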